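The source may hold more compounds than are shown below. What is called first, only, known or untested is meant among the compounds shown, and "the series" means these compounds.

Compound 1, `Cc1ccc(NC(=S)NC(=O)c2ccc(OCc3ccccc3)cc2)cc1-c1nc2ccccc2[nH]1`: in a functional assay on MGC-803 cells (Homo sapiens) for inhibition, read by MTT assay, with a stated time of 48 h (on this read-out higher numbers stand for weaker inhibition and lower numbers for stronger inhibition), compound 1 gives 60700 nM.
Compound 2, `Cc1ccc(NC(=S)NC(=O)c2ccc(OCc3cccc(F)c3)cc2)cc1-c1nc2ccccc2[nH]1`: in this assay compound 2 reaches only the limit of > 100000 nM.

Compound 2 therefore sits at the limit of > 100000 nM in this assay, at which 1 of the 2 values shown sits, with no exact number. Compound 3, `Cc1ccc(NC(=S)NC(=O)c2ccc(OCc3ccc(Cl)c(Cl)c3)cc2)cc1-c1nc2ccccc2[nH]1`, differs by 3,4-dichlorophenyl in place of 3-fluorophenyl on a saturated chain carbon bound to an oxygen on an aromatic ring. Among the compounds with values here, the one measured step, an at least 1.6-fold higher number from compound 1 to compound 2 (0.21 log units; that floor lies within the scatter), already ran toward the limit, so it bears only loosely on this further change of the benzyl ring. No shift beyond the scatter is expected, and compound 3 is expected to give about 100000 nM (range 40000 nM to 300000 nM). That means an expected step of a number no higher from compound 2 to compound 3 (the limit leaves the size open).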

Compound 3, half-maximal inhibitory concentration: 6390 nM
The estimate for compound 3 lay 16-fold (1.19 log units) above the measured number, and the stated range ends above it.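

This position turns out to respond to substitution, which the earlier step, with a floor within the scatter, could not show. In this assay, 3,4-dichlorophenyl gives a 9.5-fold lower number from compound 1 to compound 3 (0.98 log units; beyond the scatter) against the unsubstituted phenyl, and an at least 15-fold lower number from compound 2 to compound 3 (1.19 log units; beyond the scatter) against 3-fluorophenyl. The second step has only a floor, since compound 2 is held at a limit, not a number: the limit of > 100000 nM in this assay, at which 1 of the 3 values shown sits.

On these data alone, whether one chlorine alone would give the same gain remains open. So does the effect of a methoxy group or a trifluoromethyl group on this ring.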